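Swapping the Group on the Aromatic Nitrogen

A few compounds are considered here, and "the series" means these few. Any claim that something is new, unique, unknown or untested is made for them only; others in the source may bear on it.

Compound 1 `CC(C)c1onc(-c2c(Cl)cccc2Cl)c1COc1ccc(-c2nc3ccc(C(=O)O)cc3n2Cc2ccc(F)cc2)cc1`: 1140 nM
Compound 2 `CC(=O)N1CCC(n2c(-c3ccc(OCc4c(-c5c(Cl)cccc5Cl)noc4C(C)C)cc3)nc3ccc(C(=O)O)cc32)CC1`: > 10000 nM

The two measured compounds share one core and differ only in the group carried on the aromatic nitrogen. In an assay on HEK-293T cells for antagonist activity at vitamin D3 receptor (Homo sapiens), read by a luciferase reporter, with a stated time of 24 h (on this read-out lower numbers stand for stronger inhibition and higher numbers for weaker inhibition), compound 1 gives 1140 nM. For compound 2 the read-out is only a limit, > 10000 nM (the limit of > 10000 nM in this assay, at which 1 of the 2 values shown sits). The step of an at least 8.7-fold higher number from compound 1 to compound 2 (0.94 log units; beyond the scatter) is therefore known only as a lower bound on the loss. Compound 3 `CC(C)c1onc(-c2c(Cl)cccc2Cl)c1COc1ccc(-c2nc3ccc(C(=O)O)cc3n2C2CCC2)cc1` keeps the rest of the structure and alters the same position: cyclobutyl in place of 1-acetylpiperidin-4-yl on an aromatic nitrogen. For the measured compounds named here, the one measured step that bears on it, an at least 8.7-fold higher number from compound 1 to compound 2 (0.94 log units; beyond the scatter), shows that changing this group away from 4-fluorobenzyl can cost a good deal, but no measured compound carries a small carbocycle there, so the size of the new step is open. Compound 3 is expected to give roughly 3500 nM, within 800 nM to 15000 nM, which amounts to an estimated step of an at least 2.8-fold lower number from compound 2 to compound 3 (0.45 log units; beyond the scatter) toward stronger inhibition.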

Compound 3, half-maximal inhibitory concentration: 1100 nM
Estimate against measurement, compound 3: 3.2-fold (0.50 log units) above, and the stated range covers the measured number.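

In this assay, leaving 4-fluorobenzyl for cyclobutyl on the aromatic nitrogen brings no change beyond the scatter, with a 1.0-fold lower number from compound 1 to compound 3 (0.02 log units; within the scatter), so an aromatic benzyl group is not required at this position for this level of inhibition. The loss seen with compound 2 is therefore not a general cost of replacing 4-fluorobenzyl; among these compounds it goes with 1-acetylpiperidin-4-yl alone, as an at least 9.0-fold lower number from compound 2 to compound 3 (0.95 log units; beyond the scatter) shows. Compound 2 has only a limit and not a number, so that step is a bound: the limit of > 10000 nM in this assay, at which 1 of the 3 values shown sits.

The compounds shown do not tell whether the loss lies with the acetyl group, the ring nitrogen or the six-membered ring of 1-acetylpiperidin-4-yl. Cyclohexyl, an unacetylated piperidin-4-yl amine or a short open chain such as isopropyl on this nitrogen would bear on that question.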